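Ethyl for Allyl on a Selenocyanate Carbamate

The compounds below may be only part of what the source reports. "The series", "measured", "known", "first", "only" and "open" are said of these compounds alone.

Measured compounds in a functional assay on HT-29 cells (Homo sapiens) for cytotoxicity, read by MTT assay, with a stated time of 72 h; on this read-out higher numbers stand for weaker inhibition of growth and lower numbers for stronger inhibition of growth:
Compound 1 `CC(C)COC(=O)Nc1ccc([Se][Se]c2ccc(NC(=O)OCC(C)C)cc2)cc1`: 19900 nM
Compound 2 `C=CCOC(=O)Nc1ccc([Se]C#N)cc1`: 24500 nM
Compound 3 `O=C(Nc1ccc([Se][Se]c2ccc(NC(=O)OCc3ccc([N+](=O)[O-])cc3)cc2)cc1)OCc1ccc([N+](=O)[O-])cc1`: 16700 nM

The three measured compounds sit close together. Compound 2 carries the highest number of the three, but its gap to compound 1 and its gap to compound 3 both fall within the usual scatter of repeated measurements, so on these numbers the three compounds are not told apart. Among the compounds with values here, no pair of measured compounds differs in a single place, so no measured step is available to calibrate the change at hand.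

Compound 4 `CCOC(=O)Nc1ccc([Se]C#N)cc1` differs from compound 2 by a single change:
methyl in place of vinyl on a saturated chain carbon bound to an oxygen next to a carbonyl group
The change sits on the carbamate chain and leaves the selenocyanate and the rest of the core of compound 2 untouched. With the measured compounds showing no spread beyond the scatter, the step from compound 2 to compound 4 is expected to be none beyond the scatter, in this assay as a 1.0-fold higher number from compound 2 to compound 4 (0.01 log units; within the scatter). Compound 4 is therefore estimated at 25000 nM, with a range from 10000 nM to 60000 nM.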

Compound 4, concentration for 50% growth inhibition: 9300 nM
For compound 4 the middle estimate is 2.7-fold (0.43 log units) above the measured one; the whole stated range lies above it.
By their numbers in this assay, from the lowest: compounds 4, 3, 1 and 2 (each within the scatter of the next, the first and the last beyond it).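

In this assay, the carbamate chain proves not to be a silent place: allyl to ethyl gives a 2.6-fold lower number from compound 2 to compound 4 (0.42 log units; beyond the scatter), a modest step but one beyond the scatter, towards stronger inhibition of growth. The earlier compounds shown here could not show this, as no two of them differed in one place and their numbers were not told apart; here the selenocyanate and the rest of the core stay the same, so the step belongs to this one change, in which vinyl leaves and methyl enters on a saturated chain carbon bound to an oxygen next to a carbonyl group. No measurement among the data shown accounts for the step.

The compounds shown leave open whether the step goes with the loss of the double bond or with the shorter chain, a question that a propyl chain in the same place would address, as it keeps the length of allyl without the double bond. From the compounds shown here alone, it also stays open whether a step of this size would carry over to compounds without the selenocyanate, such as compound 1 and compound 3.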